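Urea to amide swap on the anilide carbonyl

The source may hold more compounds than are shown below. What is called first, only, known or untested is meant among the compounds shown, and "the series" means these compounds.

Measured compounds:
- Compound 1, `COc1cc(-c2nn(-c3cccc(NC(=O)c4ccc(Cl)c(C(F)(F)F)c4)c3)cc2-c2ccncc2)ccc1Cl`: in a functional assay on SR cells (Homo sapiens) for inhibition, read by sulforhodamine B assay, with a stated time of 48 h (a higher number here means a weaker inhibitor of growth, a lower number a stronger inhibitor of growth), compound 1 reaches only the limit of > 32500 nM.
- Compound 2, `O=C(Nc1cccc(-n2cc(-c3ccncc3)c(-c3ccc(Cl)c(O)c3)n2)c1)Nc1cc(C(F)(F)F)cc(C(F)(F)F)c1`: in this assay compound 2 gives 3660 nM.
- Compound 3, `COc1cc(-c2nn(-c3cccc(NC(=O)Nc4cccc(C(F)(F)F)c4)c3)cc2-c2ccncc2)ccc1Cl`: in this assay compound 3 gives 2840 nM.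

Compound 3 holds the lowest of the two numbers in this assay, but compound 2 sits within the scatter of it, so no order between the two can be read. For the measured compounds named here, the only other value, that of compound 1, is a limit (the limit of > 32500 nM in this assay, at which 1 of the 3 values shown sits).

Compound 4, `COc1cc(-c2nn(-c3cccc(NC(=O)c4ccccc4)c3)cc2-c2ccncc2)ccc1Cl`, is not yet measured in this assay. It differs from compound 3 by phenyl in place of (3-(trifluoromethyl)phenyl)amino on a carbonyl carbon. Going by the values given here, the one measured step that bears on this place is an at least 11-fold lower number from compound 1 to compound 3 (1.05 log units; beyond the scatter), where a urea replaced an amide and the number fell by a large margin. The change to compound 4 runs the other way: the amide-type nitrogen of the urea is lost and a plain phenyl sits on the carbonyl carbon, giving an amide as in compound 1, though without the trifluoromethyl and chloro groups. A step back up toward the weaker end is therefore expected for compound 4, of roughly the size an 8.8-fold higher number from compound 3 to compound 4 (0.94 log units; beyond the scatter), with a real chance that only a limit is reported. Compound 4 is estimated at 25000 nM, within 7000 nM to 90000 nM.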

Compound 4, concentration for total growth inhibition: > 100000 nM
Compound 4 gave a limit, no number (the forecaster's own chance of this, stated with the estimate: 45%); middle value at least 4.0-fold (0.60 log units) from the limit.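

Replacing (3-(trifluoromethyl)phenyl)amino with phenyl on the carbonyl carbon gives an at least 35-fold higher number from compound 3 to compound 4 (1.54 log units; beyond the scatter), so this position tolerates the loss of that group poorly, and the drop in growth inhibition is large even against a urea that itself sits only in the micromolar range. Compound 4 gives a limit, not a number: the limit of > 100000 nM in this assay, at which 1 of the 4 values shown sits. Compound 1 also gives only a limit: the limit of > 32500 nM in this assay, at which 1 of the 4 values shown sits. The step between these two amides cannot be read, but together they show that neither the bare phenyl nor the 4-chloro-3-(trifluoromethyl)phenyl on the carbonyl carbon brings a measurable number here, whereas the urea compound 3 does.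

The step from compound 3 to compound 4 removes the nitrogen with its hydrogen-bond donor and the trifluoromethyl group together, so the compounds shown cannot say which of the two carries the difference. A plain phenylamino on the same carbonyl carbon would separate them, and a benzyl or a longer alkyl chain there would test whether the urea nitrogen itself is needed.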